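This account rests on a few compounds, and the source may have more. Where it says the series, first, only, none or still open, it means among the compounds named here.

Measured compounds:
compound 1 `O=C1C=C(NCc2ccccc2)C(=O)c2c1nc1n2[C@H]2OC[C@@H](O)[C@H]2OC1`: 2670 nM
compound 2 `CCOc1ccc(NC2=CC(=O)c3c(nc4n3[C@H]3OC[C@@H](O)[C@H]3OC4)C2=O)cc1`: 2090 nM
compound 3 `COc1ccc(NC2=CC(=O)c3nc4n(c3C2=O)[C@H]2OC[C@@H](O)[C@H]2OC4)cc1`: 1680 nM

All three compounds share one core and were tested in a functional assay on MGC-803 cells (Homo sapiens) for inhibition, read by sulforhodamine B assay; a higher number here means a weaker inhibitor, a lower number a stronger inhibitor. Compound 2 sits among them with 2090 nM, and its value differs from those of compound 1 and compound 3 by less than the usual scatter of the assay, so none of the three can be set apart from the others on these numbers.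

Compound 4 `O=C1C(Nc2cccc(F)c2)=CC(=O)c2c1nc1n2[C@H]2OC[C@@H](O)[C@H]2OC1` is not yet measured. Its change from compound 2 is 3-fluorophenyl in place of 4-ethoxyphenyl on an amine nitrogen. Among the compounds with values here, only one measured step touches the group on this amine nitrogen: a 1.6-fold lower number from compound 1 to compound 3 (0.20 log units; within the scatter). The values of compound 2 and compound 3 likewise show that exchanging one substituted phenyl for another leaves the number where it was. Nothing here shows that the group on this nitrogen moves the number beyond the scatter, so the step in this assay from compound 2 to compound 4 is expected to be a 1.0-fold higher number from compound 2 to compound 4 (0.00 log units; within the scatter). Compound 4 is therefore estimated at 2100 nM, with a range from 1000 nM to 4400 nM.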

Compound 4, half-maximal inhibitory concentration: 1470 nM
For compound 4 the middle estimate is 1.4-fold (0.15 log units) above the measured one, within the range that was stated.
By their numbers in this assay, from the lowest: compounds 4, 3, 2 and 1 (each within the scatter of the next).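

In this assay, replacing 4-ethoxyphenyl with 3-fluorophenyl on the amine nitrogen gives a 1.4-fold lower number from compound 2 to compound 4 (0.15 log units; within the scatter). This is the first step shown that removes the oxygen-linked chain from the phenyl ring and puts a fluorine on the ring instead, and even this change, which also leaves a smaller group on the nitrogen, does not move the number beyond the scatter. Nothing given here offers an explanation for how little the number responds to this exchange.

Still open is whether any group on this nitrogen can move the number beyond the scatter, since every group shown so far is an aromatic ring of carbon, either directly attached or through one carbon. A phenyl ring carrying an amine or a carboxylic acid, or a longer alkyl chain on the nitrogen, would test this.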